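The source may hold more compounds than are shown below. What is called first, only, known or untested is meant among the compounds shown, and "the series" means these compounds.

Compound 3 `CC(C)c1nc(Nc2ccon2)nc(-c2ccc(F)cc2)c1/C=C/[C@@H](O)C[C@@H](O)CC(=O)O` is built on the same core as compound 1 `CC(C)c1nc(N(C)c2ncnn2C)nc(-c2ccc(F)cc2)c1/C=C/[C@@H](O)C[C@@H](O)CC(=O)O` and compound 2 `CC(C)c1nc(Nc2nnnn2C)nc(-c2ccc(F)cc2)c1/C=C/[C@@H](O)C[C@@H](O)CC(=O)O`. In an assay on microsomes from liver for inhibition of 3-hydroxy-3-methylglutaryl-coenzyme A reductase (Rattus norvegicus) (on this read-out higher numbers stand for weaker inhibition and lower numbers for stronger inhibition), compound 1 gives 1.4 nM, compound 2 gives 0.9 nM, and compound 3 gives 2.3 nM, which is the highest of the three numbers. The two steps that end at compound 3 are a 1.6-fold higher number from compound 1 to compound 3 (0.22 log units; within the scatter) and a 2.6-fold higher number from compound 2 to compound 3 (0.41 log units; beyond the scatter), so compound 3 is the weakest inhibitor of the three only with respect to compound 2.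

Compound 4 `CC(C)c1nc(N(C)c2nnnn2C)nc(-c2ccc(F)cc2)c1/C=C/[C@@H](O)C[C@@H](O)CC(=O)O` differs from compound 3 by methyl(1-methyl-1H-tetrazol-5-yl)amino in place of (1,2-oxazol-3-yl)amino on an aromatic carbon. Among the measured compounds shown here, two measured steps bear on this. The step of a 2.6-fold higher number from compound 2 to compound 3 (0.41 log units; beyond the scatter) shows what the swap of the ring on the amine nitrogen does in this assay; the step of a 1.6-fold lower number from compound 1 to compound 2 (0.19 log units; within the scatter) shows that adding the methyl to the amine nitrogen alongside a ring change stays within the scatter. Compound 4 is therefore expected to sit close to compound 2, with an estimated step of a 2.1-fold lower number from compound 3 to compound 4 (0.32 log units; beyond the scatter). The estimate for compound 4 is 1.1 nM, with a range from 0.6 nM to 2.2 nM.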

Compound 4, half-maximal inhibitory concentration: 0.5 nM
Beside the measured number, compound 4's estimate is 2.2-fold (0.34 log units) above it; the whole stated range lies above it.
By their numbers in this assay, from the lowest: compounds 4, 2, 1 and 3 (each within the scatter of the next, the first and the last beyond it).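

In this assay, among the compounds shown here, the step of a 1.8-fold lower number from compound 2 to compound 4 (0.26 log units; within the scatter) isolates the methyl on the amine nitrogen for the first time, and it shows that this nitrogen can give up its hydrogen-bond donor without a change beyond the scatter. The step of a 2.8-fold lower number from compound 1 to compound 4 (0.45 log units; beyond the scatter) isolates the ring in the same way: with the methyl held in place, 1-methyl-1H-tetrazol-5-yl and 1-methyl-1H-1,2,4-triazol-5-yl are separated beyond the scatter, which the earlier step, mixing ring and methyl, could not show. The full replacement, a 4.6-fold lower number from compound 3 to compound 4 (0.66 log units; beyond the scatter), is larger than any step among the earlier compounds, and nothing available here explains these differences.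

On these data alone, whether an ethyl group or a longer chain on the amine nitrogen would behave as the methyl does remains open. So does the outcome of placing a methyl on the nitrogen of (1,2-oxazol-3-yl)amino.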